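The source may report more compounds than this note shows. Statements on the series, on what has been measured and on what is new or still open speak of the compounds shown alone.

Measured compounds in an assay on cells for antagonist activity at transient receptor potential cation channel subfamily V member 1 (Homo sapiens), read by FLIPR and calcium flux, with a stated time of 6 min; a lower number here means a stronger inhibitor, a higher number a weaker inhibitor:
Compound 1 `CCCCN(C)c1cc(C(C)(C)C)ccc1CNC(=O)C(C)c1ccc(NS(C)(=O)=O)c(F)c1`: 1 nM
Compound 2 `CC(C(=O)NCc1ccc(C(C)(C)C)cc1N1CCCC1)c1ccc(NS(C)(=O)=O)c(F)c1`: 8.1 nM
Compound 3 `CC(C(=O)NCc1ccc(C(C)(C)C)cc1N1CCCCC1)c1ccc(NS(C)(=O)=O)c(F)c1`: 1.9 nM

Compound 3 holds the second highest of these three numbers. The nearest of the others lies a 1.9-fold higher number from compound 1 to compound 3 (0.28 log units; within the scatter) away, a gap within the usual scatter, while the furthest lies a 4.3-fold lower number from compound 2 to compound 3 (0.63 log units; beyond the scatter) away. Compound 4 `CC1CCN(c2cc(C(C)(C)C)ccc2CNC(=O)C(C)c2ccc(NS(C)(=O)=O)c(F)c2)CC1` differs from compound 3 by methyl in place of hydrogen on a saturated ring carbon. Among the measured compounds shown here, none of the measured steps touches a saturated ring carbon in this way. The steps of an 8.1-fold higher number from compound 1 to compound 2 (0.91 log units; beyond the scatter) and a 4.3-fold lower number from compound 2 to compound 3 (0.63 log units; beyond the scatter) exchange a chain for a ring or one ring size for another on the aromatic carbon, and the step of a 1.9-fold higher number from compound 1 to compound 3 (0.28 log units; within the scatter) stays within the scatter. A single methyl on the ring is a smaller alteration of the structure than any of these, so the step of a 1.3-fold lower number from compound 3 to compound 4 (0.10 log units; within the scatter) is expected to remain within the scatter, with no direction that can be trusted. Compound 4 is estimated at 1.5 nM, with a range from 0.5 nM to 5 nM.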

Compound 4, inhibition constant: 0.7 nM
The estimate for compound 4 lay 2.1-fold (0.33 log units) above the measured number, and the stated range covers the measured number.
By their numbers in this assay, from the lowest: compounds 4, 1 and 3 (each within the scatter of the next, the first and the last beyond it); then compound 2.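

In this assay, adding one methyl to the saturated ring carbon three ring bonds from the ring nitrogen is enough to shift the number beyond the scatter (a 2.7-fold lower number from compound 3 to compound 4 (0.43 log units; beyond the scatter)), so this position responds to a far smaller change than the earlier swaps of chain or ring size. The 4-methylpiperidin-1-yl group stands well apart from pyrrolidin-1-yl (a 12-fold lower number from compound 2 to compound 4 (1.06 log units; beyond the scatter)), but it cannot be separated from the open butyl(methyl)amino chain (a 1.4-fold lower number from compound 1 to compound 4 (0.15 log units; within the scatter)). Nothing at hand accounts for the effect of the methyl.

As far as these compounds go, it remains open whether an ethyl, a hydroxyl or a second methyl on this ring carbon would continue the shift or reverse it. Also open, from the compounds shown here alone, is how a morpholin-4-yl ring would compare on the same aromatic carbon.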